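Nucleoside series: 5'-ester change from compound 1 to compound 4

The source may report more compounds than this note shows. Statements on the series, on what has been measured and on what is new or still open speak of the compounds shown alone.

Measured compounds
- compound 1 `Nc1ncnc2c1ncn2[C@@H]1O[C@H](COC(=O)OCc2ccccc2)[C@@H](O)[C@H]1O`: > 100000 nM
- compound 2 `Nc1ncnc2c1nc(NCc1ccccc1-c1ccccc1)n2[C@@H]1O[C@H](CO)[C@@H](O)[C@H]1O`: > 100000 nM
- compound 3 `Nc1ncnc2c1nc(NCc1ccc(-c3ccccc3)cc1)n2[C@@H]1O[C@H](CO)[C@@H](O)[C@H]1O`: 640 nM

Compound 1 is tested in an assay on COS-7 cells for inhibition of sodium/nucleoside cotransporter 2 (Homo sapiens), read by scintillation counting, in the presence of a further agent that is not named here; a higher number here means a weaker inhibitor, a lower number a stronger inhibitor. For compound 1 the result > 100000 nM is a limit of the assay, not a number. For compound 2 the result > 100000 nM is likewise a limit. Compound 3 gives a number, 640 nM. Compound 1 and compound 2 together make up (the limit of > 100000 nM in this assay, at which 2 of the 3 values shown sit), and compound 3 stands apart from them. For the measured compounds named here, no pair among the measured compounds differs in one place only, so no measured step is available, and compound 3 is not a guide for the change considered here.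

Compound 4 `CCCCCC(=O)OC[C@H]1O[C@@H](n2cnc3c(N)ncnc32)[C@H](O)[C@@H]1O` is not yet measured. Its difference from compound 1 is pentyl in place of benzyloxy on a carbonyl carbon. Since compound 1 sits at the limit, the step to compound 4 can be expected to stay within the scatter only in the sense that another limit is the most likely outcome; the expected step of a number no higher from compound 1 to compound 4 (the limit leaves the size open) is therefore essentially none beyond the scatter, with a measurable number regarded as unlikely. For compound 4 the estimate in this assay is 100000 nM, with a range from 30000 nM to 300000 nM.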

Compound 4, half-maximal inhibitory concentration: > 100000 nM
Compound 4 ended at the assay's limit; the forecaster's own chance of this, stated with the estimate: 70%; the middle value lies on the limit itself.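

No step can be read from compound 1 to compound 4, because the result for each in this assay is a limit and not a number: the limit of > 100000 nM in this assay, at which 3 of the 4 values shown sit.

The compounds shown leave open whether pentyl in place of benzyloxy on a carbonyl carbon changes inhibition at all.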